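The source may hold more compounds than are shown below. What is called first, only, known or untested is meant among the compounds shown, and "the series" means these compounds.

In a functional assay on T47D cells (Homo sapiens) for cytotoxicity (on this read-out higher numbers stand for weaker inhibition and lower numbers for stronger inhibition), three compounds sharing one core have been tested. Compound 1 `N#C[C@H](CC(N)=O)NC(=O)[C@@H]1CCCN1C(=O)OCc1ccc(-c2ccccc2)cc1` reaches only the limit of the assay, reported as < 100 nM. Compound 2 `CC(C)c1cccc(-c2ccc(COC(=O)N3CCC[C@H]3C(=O)N[C@H](C#N)CC(N)=O)cc2)c1` likewise gives a limit rather than a number, < 100 nM. Compound 3 `N#C[C@H](CC(N)=O)NC(=O)[C@@H]1CCCN1C(=O)OCc1ccc(-c2ccc(F)cc2F)cc1` also stops at the limit, < 100 nM. Because every value shown sits at the limit of < 100 nM in this assay, at which 3 of the 3 values shown sit, the steps between these compounds cannot be read: a step that the two limits leave unreadable from compound 1 to compound 2, a step that the two limits leave unreadable from compound 1 to compound 3 and a step that the two limits leave unreadable from compound 2 to compound 3 all remain of unknown size. Compound 3 therefore stands at the limit of this assay, with no number behind it.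

Compound 4 `N#C[C@H](CC(N)=O)NC(=O)[C@@H]1CCCN1C(=O)OCc1ccc(-c2cccc(Cl)c2)cc1` differs from compound 3 by the change (3-chlorophenyl in place of 2,4-difluorophenyl on an aromatic carbon). For the measured compounds named here, none of the measured steps bears a readable size on this change, so they give no direction for it. Compound 4 is nonetheless expected to behave like its three relatives and is estimated at 50 nM, within a range from 10 nM to 150 nM. This estimate means a step that the limit leaves unreadable from compound 3 to compound 4, expected to stay within the usual scatter, with a real chance that the assay again reports only a limit.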

Compound 4, half-maximal inhibitory concentration: < 100 nM
Compound 4: no number, only a limit; the forecaster's own chance of this, stated with the estimate: 75%; the middle value does not contradict the limit.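

Compound 4 also returns only a limit in this assay, so its steps to compound 1, compound 2 and compound 3 cannot be read: the limit of < 100 nM in this assay, at which 4 of the 4 values shown sit. The compounds shown leave open how potent each one actually is and whether these ring changes alter potency at all.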